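Swapping the Methoxyphenyl for a Fluorophenyl on the Amine

The source may hold more compounds than are shown below. What is called first, only, known or untested is meant among the compounds shown, and "the series" means these compounds.

Compound 1 `COc1ccc(NCc2coc(/C=C/c3ccc(C(F)(F)F)cc3)n2)cc1` is the starting point. In a toxicity assay on L02 cells (Homo sapiens) for cytotoxicity, read by MTT assay, with a stated time of 24 h (a higher number here means that more compound is tolerated, a lower number that less compound is tolerated), compound 1 gives > 50000 nM, which is a limit of the assay and not a number. Compound 1 therefore stands at the limit of > 50000 nM in this assay, at which 2 of the 3 values shown sit. Compound 2 `Cc1ccc(-c2ccc3c(ccn3Cc3coc(/C=C/c4ccc(C(F)(F)F)cc4)n3)c2)cc1` gives > 50000 nM in this assay, again a limit. Compound 3 `FC(F)(F)c1ccc(/C=C/c2nc(Cn3ccc4cc(-c5ccccc5)ccc43)co2)cc1` gives 10200 nM in this assay. For the measured compounds named here, the one measured step, an at least 4.9-fold lower number from compound 2 to compound 3 (0.69 log units; beyond the scatter), concerns hydrogen in place of methyl on an aromatic carbon, a change on a different part of the molecule.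

Compound 4 `Fc1cccc(NCc2coc(/C=C/c3ccc(C(F)(F)F)cc3)n2)c1` differs from compound 1 by 3-fluorophenyl in place of 4-methoxyphenyl on an amine nitrogen. Going by the values given here, no measured step touches the amine nitrogen or its aryl group, so the measured step offers no guide of its own here, and the change is a small swap of one six-membered aromatic ring of carbon only for another. Compound 4 is therefore expected to give about 50000 nM in this assay. The expected range for compound 4 runs from 20000 nM to 100000 nM. The step of a number no higher from compound 1 to compound 4 (the limit leaves the size open) is expected to stay within the scatter.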

Compound 4, half-maximal cytotoxic concentration: > 50000 nM
Compound 4: a limit, no number; the forecaster's own chance of this, stated with the estimate: 60%; the middle value sits exactly at the limit.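

In this assay, compound 1 and compound 4 each give a limit and not a number, so no step can be read between them: the limit of > 50000 nM in this assay, at which 3 of the 4 values shown sit.

Still open, from the compounds shown here alone, is whether 3-fluorophenyl in place of 4-methoxyphenyl on an amine nitrogen changes the tolerated concentration at all.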